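Compound 3: 2-bromophenyl in place of 3-chlorophenyl

The source may hold more compounds than are shown below. What is called first, only, known or untested is meant among the compounds shown, and "the series" means these compounds.

Compound 1 `COc1ccc(C(=O)c2cc(C)ccc2OCC(=O)NNC(=O)c2cc3ccccc3oc2=O)cc1`: 41200 nM
Compound 2 `Cc1ccc(OCC(=O)NNC(=O)c2cc3ccccc3oc2=O)c(C(=O)c2cccc(Cl)c2)c1`: 65400 nM

In a functional assay on Ehrlich cells (Mus musculus) for cytotoxicity, read by LDH release, with a stated time of 48 h (a lower number here means a stronger inhibitor, a higher number a weaker inhibitor), compound 2 gives 65400 nM, which lies within the usual scatter of repeated measurements from compound 1 at 41200 nM. The next compound, compound 3 `Cc1ccc(OCC(=O)NNC(=O)c2cc3ccccc3oc2=O)c(C(=O)c2ccccc2Br)c1`, differs from compound 2 by one group: 2-bromophenyl in place of 3-chlorophenyl on a carbonyl carbon. In short, 2-bromophenyl stands in place of 3-chlorophenyl on a carbonyl carbon. Within the data shown here, only one measured step bears on this change: a 1.6-fold higher number from compound 1 to compound 2 (0.20 log units; within the scatter). That step exchanged the group on the same carbonyl carbon and stayed within the scatter. Among the measured compounds shown here, no measured compound yet carries 2-bromophenyl, so the evidence is indirect. No step beyond the scatter is therefore expected in this assay, in either direction. The estimated step is a 1.3-fold lower number from compound 2 to compound 3 (0.10 log units; within the scatter). For compound 3 the expected value is 52000 nM, with an estimated range of 20000 nM to 125000 nM.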

Compound 3, half-maximal inhibitory concentration: 9400 nM
Estimate against measurement, compound 3: 5.5-fold (0.74 log units) above; measured number below the stated range.
By their numbers in this assay, from the lowest: compound 3; then compounds 1 and 2 (each within the scatter of the next).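

The group on this carbonyl carbon can shift the number in this assay beyond the scatter, which the swap between compound 1 and compound 2 did not show: 2-bromophenyl in place of 3-chlorophenyl gives a 7.0-fold lower number from compound 2 to compound 3 (0.84 log units; beyond the scatter), and 2-bromophenyl in place of 4-methoxyphenyl gives a 4.4-fold lower number from compound 1 to compound 3 (0.64 log units; beyond the scatter). With both steps beyond the scatter, compound 3 is the strongest inhibitor of these three. Nothing measured here explains why this group behaves differently from the other two.

The change replaces chlorine with bromine and also moves the halogen on the ring, so the two effects cannot be separated here. Compounds carrying 2-chlorophenyl or 3-bromophenyl on the same carbonyl carbon would show which of the two matters, and plain phenyl would show what any halogen adds.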